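This account rests on a few compounds, and the source may have more. Where it says the series, first, only, none or still open, it means among the compounds named here.

Three compounds sharing one core, each ending in a hydrazone linked to an aryl amide, have been tested in a functional assay on HeLa cells (Homo sapiens) for inhibition, read by sulforhodamine B assay, with a stated time of 48 h; a lower number here means a stronger inhibitor of growth, a higher number a weaker inhibitor of growth. Compound 1 `Cc1cc2c(cc1C)C(Cl)=C(C(=O)N/N=C\c1ccc(F)cc1)CCC2` gives 2200 nM. Compound 3 `COc1cc(C(=O)N/N=C/C2=C(Cl)c3ccccc3CCC2)cc(OC)c1OC` gives 770 nM. Compound 2 `O=C(N/N=C/C1=C(Cl)c2ccccc2CCC1)c1ccccc1`, which carries a plain phenyl on its amide end, reaches only the limit of the measurement, > 100000 nM. Among the three values shown, compound 2 stands at the limit (the limit of > 100000 nM in this assay, at which 1 of the 3 values shown sits), while compound 1 and compound 3 come with numbers. Compound 4 `O=C(N/N=C/C1=C(Cl)c2ccccc2CCC1)c1cccc(I)c1` is compound 2 with one change: iodo in place of hydrogen on an aromatic carbon. Among the compounds with values here, no pair of measured compounds differs in one place only, so the size of this step cannot be read from the data. Compound 3, whose aryl ring carries methoxy groups, gives 770 nM, and compound 1, whose aryl ring carries a fluoro, gives 2200 nM; both substituted rings come with numbers rather than a limit. In this assay compound 4 is therefore expected to gain beyond the scatter, by an at least 3.3-fold lower number from compound 2 to compound 4 (0.52 log units; beyond the scatter), to an estimated 30000 nM, with a range from 5000 nM to 150000 nM.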

Compound 4, concentration for 50% growth inhibition: 6300 nM
Estimate against measurement, compound 4: 4.8-fold (0.68 log units) above; the measured number falls inside the stated range.
By their numbers in this assay, from the lowest: compound 3; then compound 1; then compound 4. At a limit, above all of these: compound 2.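

In this assay, one iodo on the plain phenyl ring at the amide end gives an at least 15-fold lower number from compound 2 to compound 4 (1.20 log units; beyond the scatter). The reading for compound 2 is a limit and not a number: the limit of > 100000 nM in this assay, at which 1 of the 4 values shown sits. Within the data shown here, this is the first step here that can be read at a single place, and it shows that one heavy atom, with no ring, no hydrogen-bond donor or acceptor and no charge, is enough at this position to bring the phenyl compound to a measurable number.

Still open, on these data alone, is whether this gain belongs to iodo in particular, or whether an amine or a carboxylic acid at the same place would also give it. The compounds shown also do not tell how iodo would act elsewhere on this ring.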